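Compound 4: hydroxy in place of aromatic hydrogen

The source may hold more compounds than are shown below. What is called first, only, known or untested is meant among the compounds shown, and "the series" means these compounds.

Within the data shown here, in a functional assay on KB cells (Homo sapiens) for antiproliferative activity, with a stated time of 72 h (a lower number here means a stronger inhibitor, a higher number a weaker inhibitor), compound 2 `C=C1C=CC(=O)[C@@H]2[C@H](Cc3ccccc3)CC[C@H]12` gives 591 nM, the highest number of the three measured so far. Compound 1 `C=C1C=CC(=O)[C@@H]2[C@H](Cc3ccc(OCOC)cc3)CC[C@H]12` gives 208 nM, and compound 3 `C=C1C=CC(=O)[C@@H]2[C@H](Cc3ccc(OC)c(F)c3)CC[C@H]12` gives 2.77 nM, the lowest number of the three.

The step considered here leads to compound 4 `C=C1C=CC(=O)[C@@H]2[C@H](Cc3ccc(O)cc3)CC[C@H]12`: hydroxy in place of hydrogen on an aromatic carbon. The new hydroxy stands on an aromatic carbon, para to a large group.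

Among the measured compounds shown here, the only measured single change at this place is the loss of methoxymethoxy, with a 2.8-fold higher number from compound 1 to compound 2 (0.45 log units; beyond the scatter). That step is modest but beyond the scatter, and read backwards it ties an oxygen-linked group at this place to a lower number. For the measured compounds named here, compound 3 also lies far lower at 2.77 nM, but it differs from compound 2 in more than one place, so it sets no size for this step. Hydroxy itself has not been measured in this series, and methoxymethoxy is only a partial guide to it.

A modest move towards a lower number is therefore expected in this assay, with the expected step being a 2.7-fold lower number from compound 2 to compound 4 (0.43 log units; beyond the scatter). For compound 4 the estimated value is 220 nM, with an expected range of 60 nM to 700 nM.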

Compound 4, half-maximal inhibitory concentration: 68.8 nM
For compound 4 the middle estimate is 3.2-fold (0.50 log units) above the measured one, and the stated range covers the measured number.
By their numbers in this assay, from the lowest: compound 3; then compound 4; then compound 1; then compound 2.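

In this assay, hydroxy on this aromatic carbon, para to a large group, gives an 8.6-fold lower number from compound 2 to compound 4 (0.93 log units; beyond the scatter), so a single oxygen-bearing group at this place can shift the number by more than the loss of methoxymethoxy had suggested, which was a 2.8-fold higher number from compound 1 to compound 2 (0.45 log units; beyond the scatter). Removing the methoxymethyl from that oxygen gives a 3.0-fold lower number from compound 1 to compound 4 (0.48 log units; beyond the scatter), so the two oxygen-linked groups are not interchangeable here: the free hydroxy gives the lower number, and the three compounds that vary only at this place run from compound 4 through compound 1 to compound 2. No measured property is available that bears on this order.

Open is whether a simple methoxy, an amine or a carboxylic acid at this place would extend the trend or break it, so the three groups shown cannot yet separate the effect of the free hydroxy from that of an oxygen at this place in general. Compound 3, at 2.77 nM, differs from these compounds in more than one place, so the shares of its methoxy and its fluorine in that value remain unresolved.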